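Swapping 2-fluorophenyl for pyridin-3-yl on compound 3

This account rests on a few compounds, and the source may have more. Where it says the series, first, only, none or still open, it means among the compounds named here.

In an ADME assay (liver) for metabolic stability, with Liver microsome (Rattus norvegicus) as the target, using microsomes (on this read-out lower numbers stand for slow clearance and higher numbers for fast clearance), compound 1 `c1ccc(CNc2nnc(-c3ccc4cnccc4c3)o2)cc1` gives 166 mL.min-1.g-1, compound 2 `Fc1cc2cc(-c3nnc(NCc4ccccc4)o3)ccc2cn1` gives 56 mL.min-1.g-1 and compound 3 `Fc1ccccc1CNc1nnc(-c2c[nH]c3ncccc23)o1` gives 46 mL.min-1.g-1. Compound 3 therefore sits level with compound 2, within the usual scatter, and clearly under compound 1. The next structure, compound 4 `c1cncc(CNc2nnc(-c3c[nH]c4ncccc34)o2)c1`, carries pyridin-3-yl in place of 2-fluorophenyl on a saturated chain carbon bound to a nitrogen on an aromatic ring. Among the measured compounds shown here, only one measured step is available to lean on. Putting fluoro in place of hydrogen on an aromatic carbon gave a 3.0-fold lower number from compound 1 to compound 2 (0.47 log units; beyond the scatter), a modest change. That swap is a different one, made at another place, so it shows only that one small edit can shift this assay by a modest amount. For the measured compounds named here, no measured compound carries pyridin-3-yl, so the data say nothing direct about this change. A modest step towards a lower number is expected here, but that direction is a judgement and not a measured trend. The expected step is a 1.8-fold lower number from compound 3 to compound 4 (0.26 log units; within the scatter). The estimate for compound 4 is 25 mL.min-1.g-1, with an expected range from 10 mL.min-1.g-1 to 60 mL.min-1.g-1.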

Compound 4, intrinsic clearance in microsomes: 30 mL.min-1.g-1
The estimate for compound 4 lay 1.2-fold (0.08 log units) below the measured number; measured number inside the range.
By their numbers in this assay, from the lowest: compounds 4, 3 and 2 (each within the scatter of the next); then compound 1.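

In this assay the swap of 2-fluorophenyl for pyridin-3-yl on a saturated chain carbon bound to a nitrogen on an aromatic ring gives a 1.5-fold lower number from compound 3 to compound 4 (0.19 log units; within the scatter) and so leaves the two compounds level. Among the compounds shown here, this is the first reading at this place, as the only earlier step put fluoro in place of hydrogen on an aromatic carbon elsewhere, in a different core, and it shows that a whole ring can be exchanged here without a change larger than the usual scatter, even though the ring that enters carries a ring nitrogen and a hydrogen-bond acceptor while the ring that leaves has neither. No measurement shown here accounts for this result.

A single pair also cannot separate the loss of the fluorine from the gain of the ring nitrogen, since both happen in the same step, and it cannot show whether pyridin-3-yl would behave the same way on the core of compound 1. From the compounds shown here alone, how far this place tolerates something less like an aromatic ring, such as a saturated amine, a carboxylic acid or a longer chain, remains open.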